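The source may hold more compounds than are shown below. What is called first, only, known or untested is meant among the compounds shown, and "the series" means these compounds.

Compound 1 `Cc1ccc(N2CCN(CCCOc3ccc4c(=O)cc(-c5ccccc5)oc4c3)CC2)cc1` is the starting point. In a functional assay for antagonist activity at Adrenergic receptor alpha-1 (Rattus norvegicus) (a higher number here means weaker binding, a lower number tighter binding), compound 1 gives 20.7 nM. Compound 2 `Cc1ccccc1N1CCN(CCCOc2ccc3c(=O)cc(-c4ccccc4)oc3c2)CC1` differs from it only by 2-methylphenyl in place of 4-methylphenyl on an amine nitrogen in a ring; in this assay compound 2 gives 117 nM, which is a 5.7-fold higher number from compound 1 to compound 2 (0.75 log units; beyond the scatter). Compound 3 `Cc1ccc(N2CCN(CCCCOc3ccc4c(=O)cc(-c5ccc(Cl)cc5)oc4c3)CC2)cc1` carries a different core, and the difference between the two cores is not broken down here. In this assay compound 3 gives 3.18 nM, the lowest of the three numbers. Compound 4 `Cc1ccccc1N1CCN(CCCCOc2ccc3c(=O)cc(-c4ccc(Cl)cc4)oc3c2)CC1` has not been measured; it differs from compound 3 by 2-methylphenyl in place of 4-methylphenyl on an amine nitrogen in a ring, the same change as before, made at the same place. Because the same change gave a 5.7-fold higher number from compound 1 to compound 2 (0.75 log units; beyond the scatter), a similar-sized step is expected, namely a 5.7-fold higher number from compound 3 to compound 4 (0.75 log units; beyond the scatter). Compound 4 is therefore estimated at 18 nM, expected to fall between 6 nM and 55 nM.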

Compound 4, dissociation constant: 33.8 nM
Compound 4: the middle estimate sits 1.9-fold (0.27 log units) below what was measured; measured number inside the range.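

On the second core, 2-methylphenyl in place of 4-methylphenyl gives an 11-fold higher number from compound 3 to compound 4 (1.03 log units; beyond the scatter) in this assay. The change moves the number in the same direction on both cores, and the two steps cannot be told apart in size: the same change on two cores in this assay, a 5.7-fold higher number (0.75 log units; beyond the scatter) from compound 1 to compound 2 and an 11-fold higher number (1.03 log units; beyond the scatter) from compound 3 to compound 4, 1.9-fold (0.27 log units) apart, within the scatter of two such steps. The change therefore carries over between these two cores, but two pairs show nothing about other cores, nor why the 2-methylphenyl compounds give the higher numbers.

Still open, going by these compounds, is whether a methoxy group or a fluorine in place of the methyl would behave the same way. The compounds shown also leave open how much of the difference between the two cores comes from the chlorine and how much from the longer chain.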